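Triazole Substituent Swap and HeLa Cytotoxicity

A few compounds are considered here, and "the series" means these few. Any claim that something is new, unique, unknown or untested is made for them only; others in the source may bear on it.

Measured so far:
Compound 1: `CCCCCCCc1cn(C(c2ccccc2)c2cc3cc(Br)ccc3nc2OC)nn1` — 9.7%
Compound 2: `CCCCc1cn(C(c2ccccc2)c2cc3cc(Br)ccc3nc2OC)nn1` — -2.87%

Both compounds were tested in an ADME assay on HeLa cells (Homo sapiens) for cytotoxicity, read by sulforhodamine B assay, with a stated time of 48 h, tested at 10 uM; on this read-out lower numbers stand for less inhibition and higher numbers for more inhibition at the one concentration tested (going by the name of the read-out). Compound 2, with structure `CCCCc1cn(C(c2ccccc2)c2cc3cc(Br)ccc3nc2OC)nn1`, gives the lowest of the two numbers; its nearest neighbour is compound 1, which differs by a number 12.6 percentage points lower from compound 1 to compound 2 (beyond the scatter), a change of hydrogen in place of propyl on a saturated chain carbon, four bonds along the chain from an aromatic carbon.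

The unmeasured compound 3 has structure `COc1nc2ccc(Br)cc2cc1C(c1ccccc1)n1cc(-c2ccccc2F)nn1`. It differs from compound 2 by 2-fluorophenyl in place of butyl on an aromatic carbon. For the measured compounds named here, only one measured step is available, and it concerns shortening of a chain rather than exchange of a chain for an aromatic ring, so it bears only loosely on this change; it shows that altering the group at this position moved the read-out by a modest amount. Both measured numbers sit near zero, so compound 3 is expected to remain in the same low region, with an estimated step of a number 8.9 percentage points higher from compound 2 to compound 3 (within the scatter) from compound 2. The estimate for compound 3 in this assay is 6%, within a range from -10% to 22%.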

Compound 3, a percentage reported as inhibition, at one concentration (the size of the read-out at that concentration, not a potency): 14.1%
The estimate for compound 3 lay 8.1 percentage points below the measured number; measured number inside the range.
By their numbers in this assay, from the lowest: compound 2; then compounds 1 and 3 (each within the scatter of the next).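

In this assay, for the compounds shown here, the earlier compounds showed only a change in chain length at this position; compound 3 adds an aromatic ring on the same aromatic carbon of the five-membered ring, and 2-fluorophenyl in place of butyl gives a number 17 percentage points higher from compound 2 to compound 3 (beyond the scatter) in a step that is modest. Set against heptyl, the same ring gives a number 4.4 percentage points higher from compound 1 to compound 3 (within the scatter) and so cannot be told apart from that chain, which leaves butyl as the one group of the three that stands apart from both others at this single concentration. Nothing at hand bears on why these groups read as they do.

The compounds shown leave open whether plain phenyl, without the fluorine, would read like 2-fluorophenyl, and whether moving the fluorine to another place on that ring would alter the number. They also leave open how an amine, a carboxylic acid or a chain longer than heptyl would read at this position, and how any of these groups would behave across a range of concentrations rather than at one.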